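Aryl exchange on the shared core, compound 2 to compound 3

This account rests on a few compounds, and the source may have more. Where it says the series, first, only, none or still open, it means among the compounds named here.

Compound 2 `O=C(O)Cc1sc(C(c2ccc(F)cc2)c2ccc(F)cc2)nc1-c1cccc(F)c1` stands level with compound 1 `O=C(O)Cc1sc(C(c2ccc(F)cc2)c2ccc(F)cc2)nc1-c1ccc(Cl)cc1` in an in vitro functional assay on HEK285-7 cells for antagonist activity at prostaglandin D2 receptor 2 (Homo sapiens), read by BRET and beta-arrestin recruitment (on this read-out higher numbers stand for larger maximal responses and lower numbers for smaller maximal responses), where compound 1 gives 80% and compound 2 gives 80%; the step of no change at the digits printed from compound 1 to compound 2 (within the scatter) lies within the scatter. Compound 3 `O=C(O)Cc1sc(C(c2ccc(F)cc2)c2ccc(F)cc2)nc1-c1ccnc(F)c1` differs from compound 2 by 2-fluoropyridin-4-yl in place of 3-fluorophenyl on an aromatic carbon. Among the measured compounds shown here, only one measured step bears on this, the earlier aryl-for-aryl exchange at the same place, and it was flat, so the step of no change at the digits printed from compound 2 to compound 3 (within the scatter) is expected to stay within the scatter. For compound 3 the efficacy in this assay is estimated at 80%, with a range of 68% to 92%.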

Compound 3, largest response reached (reported as efficacy), in percent of the reference or control that the assay uses: 80%
Beside the measured number, compound 3's estimate shows no gap at the digits printed, within the range that was stated.
By their numbers in this assay, from the lowest: compounds 1, 2 and 3 (each within the scatter of the next).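

Compound 1 and compound 2 carry an aromatic ring of carbon only at this position, whereas 2-fluoropyridin-4-yl brings a ring nitrogen and a hydrogen-bond acceptor. In this assay this exchange gives no change at the digits printed from compound 2 to compound 3 (within the scatter) and, against the 4-chlorophenyl group, no change at the digits printed from compound 1 to compound 3 (within the scatter), so the read-out tolerates a hetero atom in this aromatic ring. No evidence on the reason for this flat result is at hand.

Open, as far as these compounds go, is how a non-aromatic group would read at this carbon, such as a piperidine ring, an amine or a longer alkyl chain.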